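Nitro for chloro in the aryl acrylonitrile series

This account rests on a few compounds, and the source may have more. Where it says the series, first, only, none or still open, it means among the compounds named here.

Measured in a functional assay on A-431 cells (Homo sapiens) for cytotoxicity, read by MTT assay, with a stated time of 72 h; on this read-out higher numbers stand for weaker inhibition of growth and lower numbers for stronger inhibition of growth:
- compound 1 `N#C/C(=C/c1ccc2ccccc2c1)C(=O)c1ccc[nH]1`: < 10000 nM (a limit)
- compound 2 `Cc1ccc(/C=C(/C#N)C(=O)c2ccc[nH]2)cc1`: < 10000 nM (a limit)
- compound 3 `N#C/C(=C/c1ccc(Cl)cc1)C(=O)c1ccc[nH]1`: 31000 nM

Within the data shown here, compound 3 carries the only true number, 31000 nM. The other two readings rest on (the limit of < 10000 nM in this assay, at which 2 of the 3 values shown sit).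

Compound 4 `N#C/C(=C/c1ccc([N+](=O)[O-])cc1)C(=O)c1ccc[nH]1` has nitro in place of chloro on an aromatic carbon, para to a large group (nitro in place of chloro on an aromatic carbon). Among the measured compounds shown here, the one measured step that bears on this change is an at least 3.1-fold higher number from compound 2 to compound 3 (0.49 log units; beyond the scatter). Chloro is the entering group in that step, and it sits on the side with the higher number. Its size rests on a limit, and it is a single pair. Nitro has no measured value yet in this series, so the step gives only a weak guide.

In this assay, a small shift toward a lower number is expected on leaving chloro, not clearly beyond the scatter. The estimated change is a 1.9-fold lower number from compound 3 to compound 4 (0.29 log units; within the scatter). For compound 4 the expected value is 16000 nM, with an estimated range from 4000 nM to 45000 nM.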

Compound 4, concentration for 50% growth inhibition: < 10000 nM
Compound 4 was reported as a limit; the forecaster's own chance of this, stated with the estimate: 30%; middle value at least 1.6-fold (0.20 log units) away from the limit.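

Compound 4 reads < 10000 nM in this assay, and this value is a limit. At this position, on an aromatic carbon para to a large group, nitro in place of chloro gives an at least 3.1-fold lower number from compound 3 to compound 4 (0.49 log units; beyond the scatter), and with the earlier step, an at least 3.1-fold higher number from compound 2 to compound 3 (0.49 log units; beyond the scatter), chloro now sits on the higher side against both methyl and nitro, although the size of each step rests on a limit and each is a single pair. The pattern reaches only these compounds, and the step between the methyl and nitro compounds cannot be read, since both of its values are limits: the limit of < 10000 nM in this assay, at which 3 of the 4 values shown sit.

On these data alone, whether the true values of compound 1, compound 2 and compound 4 differ from one another stays open, so no order among them can be drawn. Also open is whether the shift away from chloro would hold in this assay for an amine, a carboxylic acid or a longer chain at this position, as the compounds shown carry only methyl, chloro and nitro there.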